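The source may report more compounds than this note shows. Statements on the series, on what has been measured and on what is new or still open speak of the compounds shown alone.

Measured compounds:
compound 1 `C=CCn1c(SCC(=O)Nc2ccc(C(C)=O)cc2)nnc1-c1ccccc1` — 70%
compound 2 `C=CCn1c(SCC(=O)Nc2ccc(C(C)=O)cc2)nnc1-c1ccc(OC)c(OC)c1` — 70%

For the measured compounds named here, in a functional assay on the whole organism (strain albino) for inhibition, with Rattus norvegicus as the target, read by paw edema, with stated times of 30 min and 4 h, at a dose of 0.28 mmol/kg by the oral route (on this read-out higher numbers stand for more inhibition at the one dose given (going by the name of the read-out) and lower numbers for less inhibition), compound 1 gives 70%, and compound 2 gives 70%; the one measured step, no change at the digits printed from compound 1 to compound 2 (within the scatter), shows that swapping the phenyl on the shared core for a dimethoxy-bearing phenyl leaves the read-out where it was. Going by the values given here, compound 1 therefore stands level with its only neighbour.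

Compound 3 `CC(=O)c1ccc(NC(=O)CSc2nnc(-c3ccccc3)n2-c2ccccc2)cc1` is the next step from compound 1: phenyl in place of allyl on an aromatic nitrogen. Among the compounds with values here, this change touches a different position than the measured step, so no measured step bears directly on it; the single step that exists, no change at the digits printed from compound 1 to compound 2 (within the scatter), at least suggests that the read-out is not very sensitive to changes around the shared core. For that reason no shift beyond the scatter is expected in this assay, and compound 3 is estimated at 68%, with a range from 50% to 82%, an expected step of a number 2 percentage points lower from compound 1 to compound 3 (within the scatter).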

Compound 3, a percentage reported as inhibition, in the whole organism at one dose (the size of the read-out at that dose, not a potency): 67%
Compound 3: middle estimate off by 1 percentage points, on the high side; measured number inside the range.
By their numbers in this assay, from the lowest: compounds 3, 1 and 2 (each within the scatter of the next).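

In this assay, phenyl in place of allyl on the aromatic nitrogen gives a number 3 percentage points lower from compound 1 to compound 3 (within the scatter). For the compounds shown here, the earlier pair changed only the phenyl on an aromatic carbon, so this is the first look at the group on the nitrogen, and it shows that, in this pair, an open allyl chain with its double bond can give way to an aromatic ring without a step that stands out from the scatter. No measured property of these compounds is available to explain this result.

As far as these compounds go, it remains open whether a small methyl, or a chain ending in an amine or a carboxylic acid, on this same nitrogen would move the read-out beyond the scatter. A percentage at one dose also leaves the potency of compound 1 and compound 3 unsettled.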